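Cytotoxicity notes on a nitrobenzamide benzothiazole series

The source may report more compounds than this note shows. Statements on the series, on what has been measured and on what is new or still open speak of the compounds shown alone.

Compound 3 `O=C(Nc1cc(-c2nc3ccccc3s2)ccc1F)c1cc([N+](=O)[O-])ccc1Cl` is the point of departure. In an ADME assay on BJ cells (Homo sapiens) for cytotoxicity, with a stated time of 72 h (on this read-out higher numbers stand for an effect only at larger amounts of compound and lower numbers for an effect already at smaller amounts), compound 3 gives > 25000 nM, which is a limit of the assay and not a number. Compound 1 `O=C(Nc1cc(-c2nc3ccccc3s2)ccc1Cl)c1cc([N+](=O)[O-])ccc1Cl` differs from compound 3 in one place, carrying chloro where compound 3 carries fluoro. In this assay compound 1 gives > 25000 nM, again a limit. The step that the two limits leave unreadable from compound 1 to compound 3 is therefore not readable in size or direction. Compound 2 `Cc1ccc(-c2nc3ccccc3s2)cc1NC(=O)c1cc([N+](=O)[O-])c(N2CCC(C(=O)O)CC2)cc1Cl` belongs to the same series and also carries a methyl group together with a larger substituent. In this assay compound 2 gives > 25000 nM, a limit as well. All values shown so far sit at the same limit (the limit of > 25000 nM in this assay, at which 3 of the 3 values shown sit).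

Compound 4 `Cc1ccc(-c2nc3ccccc3s2)cc1NC(=O)c1cc([N+](=O)[O-])ccc1Cl` has not yet been measured. Its difference from compound 3 is methyl in place of fluoro on an aromatic carbon. Among the measured compounds shown here, no measured step bears directly on this change, since the only step between measured compounds, from compound 1 to compound 3, cannot be read. With every measured value at the limit, no step beyond the scatter is expected from compound 3 to compound 4, so a step that the limit leaves unreadable from compound 3 to compound 4 is taken as flat. Compound 4 is expected to return a limit again, estimated at 30000 nM, with a range from 15000 nM to 60000 nM.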

Compound 4, half-maximal effective concentration: > 14000 nM
Compound 4 was reported as a limit; the forecaster's own chance of this, stated with the estimate: 85%; the middle value lies beyond the limit too.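

In this assay compound 4 gives > 14000 nM as a limit, not a number. Among the compounds shown here, no step from compound 1, compound 2 or compound 3 to compound 4 can be read in size or direction. The compounds shown leave open at what concentration any of them affects these cells, and whether chloro, fluoro or methyl on that aromatic carbon makes any difference.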